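A few compounds are considered here, and "the series" means these few. Any claim that something is new, unique, unknown or untested is made for them only; others in the source may bear on it.

For the measured compounds named here, in a functional assay on NCI-H460 cells (Homo sapiens) for cytotoxicity, read by sulforhodamine B assay, with a stated time of 3 days (a higher number here means a weaker inhibitor, a lower number a stronger inhibitor), compound 1 `COCc1cn(Cc2ccc(Cl)cc2)c2ccccc12` gives 1990 nM, the higher of the two numbers measured so far. Compound 2 `O=C(NC1CCCCC1)OCc1cn(Cc2ccc(Cl)cc2)c2ccccc12` gives 20 nM in this assay. The step separating them, a 100-fold lower number from compound 1 to compound 2 (2.00 log units; beyond the scatter), is large and beyond the scatter, and it comes with cyclohexylcarbamoyl in place of methyl on an oxygen on a saturated carbon.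

Compound 3 `COC(=O)CNCc1cn(Cc2ccc(Cl)cc2)c2ccccc12` has not yet been measured. It carries ((methoxycarbonyl)methyl)amino in place of methoxy on a saturated chain carbon bound to an aromatic carbon.

Going by the values given here, only one measured step bears on this change, and only loosely. Compound 2 keeps the oxygen that compound 3 loses, and the group entering compound 3 has no ring. Among the compounds with values here, the single step of a 100-fold lower number from compound 1 to compound 2 (2.00 log units; beyond the scatter) therefore suggests a lower number in this assay when this part of compound 1 is enlarged, but a much smaller drop is expected here, and it may not clear the scatter. The expected change is a 4.0-fold lower number from compound 1 to compound 3 (0.60 log units; beyond the scatter). For compound 3 the estimated value is 500 nM, with an expected range from 100 nM to 2500 nM.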

Compound 3, half-maximal inhibitory concentration: 100 nM
Compound 3: the middle estimate sits 5.0-fold (0.70 log units) above what was measured; the measured number falls inside the stated range.
By their numbers in this assay, from the lowest: compound 2; then compound 3; then compound 1.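

In this assay, the change from methoxy to ((methoxycarbonyl)methyl)amino gives a 20-fold lower number from compound 1 to compound 3 (1.30 log units; beyond the scatter), so a large drop at this saturated chain carbon bound to an aromatic carbon is no longer tied to a single replacement. The entering group has no ring and attaches through nitrogen, so neither the cyclohexyl ring of compound 2 nor an oxygen at this place is required for a large drop among the compounds shown. Both replacements of the methyl or methoxy end are larger than what they replace and both lower the number, though compound 2, at 20 nM, still stands lower in the printed values than compound 3, which gives 100 nM. Nothing available explains either drop.

The compounds shown leave open which part of ((methoxycarbonyl)methyl)amino goes with the drop, since they cannot separate the secondary amine from the methyl ester at its end. A plain methylamine at this place, the carboxylic acid in place of the ester, or a longer chain between the nitrogen and the carbonyl would each bear on that question.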